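Removing the Chloro Group of Compound 3

The source may report more compounds than this note shows. Statements on the series, on what has been measured and on what is new or still open speak of the compounds shown alone.

Compound 3 `CNC(=O)c1cc(C(=O)N[C@H]2CC[C@H](O)CC2)c([C@@H](C)c2ccc(Cl)cc2)o1` has two measured companions here. In a physicochemical assay for lipophilicity (on this read-out higher numbers stand for higher lipophilicity and lower numbers for lower lipophilicity), compound 1 `CNC(=O)c1cc(C(=O)N[C@H]2[C@@H]3C[C@H](O)C[C@@H]32)n([C@@H](C)c2cccc(Cl)c2)n1` gives 3.7, and compound 2 `CNC(=O)c1cc(C(=O)N[C@H]2CC[C@H](O)CC2)n([C@@H](C)c2cccc(Cl)c2)n1` gives 3.7; the step of no change at the digits printed from compound 1 to compound 2 (within the scatter) shows that exchanging one saturated ring for another left the read-out where it was. Compound 3 gives 3.5, a number within the scatter of both compound 1 and compound 2. Compound 4 `CNC(=O)c1cc(C(=O)N[C@H]2CC[C@H](O)CC2)c([C@@H](C)c2ccccc2)o1` differs from compound 3 in one place: hydrogen in place of chloro on an aromatic carbon. Within the data shown here, none of the measured steps makes this kind of change, so no measured step bears on it, and the expectation rests on the value of compound 3 alone. Compound 4 is expected to read lower, by an estimated a number 0.60 log units lower from compound 3 to compound 4 (beyond the scatter), at 2.9 with a range from 2.5 to 3.3.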

Compound 4, distribution coefficient: 2.8
Compound 4: middle estimate off by 0.10 log units, on the high side, within the range that was stated.
By their numbers in this assay, from the lowest: compound 4; then compounds 3, 1 and 2 (each within the scatter of the next).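

In this assay, hydrogen in place of chloro on the aromatic ring gives a number 0.70 log units lower from compound 3 to compound 4 (beyond the scatter) and so provides the first step beyond the scatter among these compounds. Among these compounds, the only earlier step, a change of saturated ring on the amide nitrogen, gave no change at the digits printed from compound 1 to compound 2 (within the scatter) and did not show that this read-out can move. No measurement here accounts for the size of the new step.

From the compounds shown here alone, whether a fluoro or methoxy group at this para position would give a smaller or larger step remains open. So does whether removing chloro from compound 2 would give a similar step.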